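A few compounds are considered here, and "the series" means these few. Any claim that something is new, unique, unknown or untested is made for them only; others in the source may bear on it.

Of the compounds shown here, two have numbers so far in a functional assay on P388 cells (Mus musculus) for cytotoxicity; on this read-out lower numbers stand for stronger inhibition and higher numbers for weaker inhibition. Compound 1 (`COc1ccc(C[C@H]2C(=O)N[C@@H](C)C(=O)N(C)[C@H]3Cc4ccc(cc4)Oc4cc(ccc4OC)C[C@@H](C(=O)N[C@H](C)C(=O)N[C@@H](CCCO)C(=O)N2C)N(C)C3=O)cc1`) gives 174 nM, and compound 2 (`CCN1C(=O)[C@@H](C)NC(=O)[C@@H]2Cc3ccc(OC)c(c3)Oc3ccc(cc3)C[C@@H](C(=O)N2C)N(C)C(=O)[C@H](C)NC(=O)[C@H](Cc2ccc(OC)cc2)N(C)C(=O)[C@@H]1C`) gives 43.7 nM. Compound 2 therefore holds the lower of the two numbers, and its gap to compound 1 lies beyond the scatter. Compound 3 (`CCCN1C(=O)[C@@H](C)NC(=O)[C@@H]2Cc3ccc(OC)c(c3)Oc3ccc(cc3)C[C@@H](C(=O)N2C)N(C)C(=O)[C@H](C)NC(=O)[C@H](Cc2ccc(OC)cc2)N(C)C(=O)[C@@H]1C`) has no number yet in this assay. Its difference from compound 2 is methyl in place of hydrogen on a saturated chain carbon, two bonds along the chain from an amide-type nitrogen in a ring, which turns ethyl into propyl. For the measured compounds named here, no measured pair shows this change, so the data give no direct size for it. The expectation is a small move toward a higher number in this assay, close to the edge of the scatter, and a result with no step beyond the scatter would not be surprising. The expected size is a 1.4-fold higher number from compound 2 to compound 3 (0.14 log units; within the scatter). For compound 3 the estimated value is 60 nM, with an expected range of 20 nM to 170 nM.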

Compound 3, half-maximal inhibitory concentration: 3.98 nM
Estimate against measurement, compound 3: 15-fold (1.18 log units) above; measured number below the stated range.
By their numbers in this assay, from the lowest: compound 3; then compound 2; then compound 1.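

In this assay, the alkyl chain at this place is not a silent position: ethyl to propyl, with methyl in place of hydrogen on a saturated chain carbon, two bonds along the chain from an amide-type nitrogen in a ring, gives an 11-fold lower number from compound 2 to compound 3 (1.04 log units; beyond the scatter). This pair provides the series' first direct size for a change that differs in one place, and it shows that a single added carbon, with no hydrogen-bond donor, acceptor or net charge entering, can carry a large step toward stronger inhibition. Nothing available bears on what lies behind the size of this step.

As far as these compounds go, with only ethyl and propyl compared here, a single step defines no trend, and the shape of the chain-length relationship remains open. A longer chain such as butyl would show whether the number keeps falling past propyl, while a branched isopropyl group, or a propyl chain ending in an amine or a carboxylic acid, would show how much of the step survives when the chain is reshaped or its end is changed.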